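From quinolin-2-yl to 2-methoxyphenyl on the carbonyl carbon

The source may report more compounds than this note shows. Statements on the series, on what has been measured and on what is new or still open speak of the compounds shown alone.

Going by the values given here, in a functional assay on SK-BR-3 cells (Homo sapiens) for antiproliferative activity, read by MTT assay, with a stated time of 72 h (a lower number here means a stronger inhibitor, a higher number a weaker inhibitor), compound 2 `CCN1CCN(c2cc(C)c3cc(NC(=O)c4ccc5ccccc5n4)ccc3n2)CC1` gives 3760 nM, the lower of the two numbers so far, and compound 1 `CCN1CCN(c2cc(C)c3cc(NC(=O)c4ccc(F)cc4)ccc3n2)CC1` gives 19800 nM. Compound 3 `CCN1CCN(c2cc(C)c3cc(NC(=O)c4ccccc4OC)ccc3n2)CC1` keeps the shared core and differs from compound 2 at one place: 2-methoxyphenyl in place of quinolin-2-yl on a carbonyl carbon. In words, this is 2-methoxyphenyl in place of quinolin-2-yl on a carbonyl carbon.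

Among the compounds with values here, only one measured step bears on this change: a 5.3-fold lower number from compound 1 to compound 2 (0.72 log units; beyond the scatter). Compound 3 again has a phenyl group on the carbonyl carbon, so a modest rise in this assay is expected, part of the way back towards compound 1 at 19800 nM. Within the data shown here, no measured compound carries 2-methoxyphenyl, and the range stays wide. The expected step is a 2.9-fold higher number from compound 2 to compound 3 (0.47 log units; beyond the scatter). The estimate for compound 3 is 11000 nM, with an expected range from 4000 nM to 30000 nM.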

Compound 3, half-maximal inhibitory concentration: 15700 nM
The estimate for compound 3 lay 1.4-fold (0.15 log units) below the measured number; low and high end bracket the measured number.
By their numbers in this assay, from the lowest: compound 2; then compounds 3 and 1 (each within the scatter of the next).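

In this assay the gain carried by quinolin-2-yl on the carbonyl carbon does not survive the change to 2-methoxyphenyl, with a 4.2-fold higher number from compound 2 to compound 3 (0.62 log units; beyond the scatter) as the step. The second phenyl-bearing amide also adds a comparison that the earlier pair could not give: a 1.3-fold lower number from compound 1 to compound 3 (0.10 log units; within the scatter) shows that 2-methoxyphenyl and 4-fluorophenyl cannot be told apart here, and of these three groups only quinolin-2-yl stands apart, with the lowest number. Nothing available gives a reason for this result.

On these data alone, whether the lower number of compound 2 goes with the second aromatic ring or with the ring nitrogen of quinolin-2-yl stays open. Naphthalen-2-yl and pyridin-2-yl on the same carbonyl carbon would separate those two features.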